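Amide amine variation on a sulfonylpiperazine core

The compounds below may be only part of what the source reports. "The series", "measured", "known", "first", "only" and "open" are said of these compounds alone.

Compound 1 `CC(C(=O)N1CCCCC1)N1CCN(S(=O)(=O)c2ccc(C(C)(C)C)cc2)CC1` is the reference point of this set in an ADME assay on HepG2 cells (Homo sapiens) for inhibition, with a stated time of 48 h; on this read-out higher numbers stand for an effect only at larger amounts of compound and lower numbers for an effect already at smaller amounts. In this assay compound 1 gives only a limit of the assay, > 40000 nM, and no number. Compound 2 `CCC1(CC)c2ccccc2CCN1C(=O)C(C)N1CCN(S(=O)(=O)c2ccc(C(C)(C)C)cc2)CC1` carries a different amine on the amide carbonyl; in this assay compound 2 likewise reaches only a limit, > 40000 nM. Among the measured compounds shown here, both values shown thus sit at the limit of > 40000 nM in this assay, at which 2 of the 2 values shown sit, so compound 1 stands level with the single other measured compound and no step between measured compounds can be stated, nor any ordering within the pair.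

Compound 3 `CC(C(=O)N1CCc2ncccc2C1)N1CCN(S(=O)(=O)c2ccc(C(C)(C)C)cc2)CC1` is not yet measured. It differs from compound 1 on the carbonyl carbon whose other neighbour is a saturated chain carbon: a group of 10 heavy atoms (8 carbon, 2 nitrogen; one six-membered non-aromatic ring with 1 hetero atom, one six-membered aromatic ring with 1 hetero atom) in place of a group of 6 heavy atoms (5 carbon, 1 nitrogen; one six-membered non-aromatic ring with 1 hetero atom), on a carbonyl carbon. With both measured compounds at a limit, the step from compound 1 to compound 3 in this assay is expected to be none beyond the scatter, that is a step that the limit leaves unreadable from compound 1 to compound 3. For compound 3 the estimated value in this assay is 60000 nM, with an expected range from 20000 nM to 200000 nM, and most probably the assay will again report only a limit.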

Compound 3, half-maximal effective concentration: > 40000 nM
Compound 3 ended at the assay's limit; the forecaster's own chance of this, stated with the estimate: 80%; the middle value is on the limit's open side.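

The step from compound 1 to compound 3 cannot be read in this assay, since both compounds end at a limit of the assay: the limit of > 40000 nM in this assay, at which 3 of the 3 values shown sit.

The compounds shown leave open whether any amine on the amide carbonyl of the shared core gives a numerical half-maximal effective concentration in this assay, and how compound 1, compound 2 and compound 3 would order.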